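The compounds below may be only part of what the source reports. "The series", "measured", "known", "first", "only" and "open" are said of these compounds alone.

Compound 1 `COc1ccccc1-c1csc(N/N=C/c2ccc(F)c(F)c2)n1`: 25200 nM
Compound 2 `Fc1ccc(/C=N/Nc2nc(-c3cccc(Br)c3)cs2)cc1F`: 17500 nM
Compound 3 `COc1ccccc1-c1csc(N/N=C/c2cc(OC)c(OC)c(Br)c2Br)n1`: > 100000 nM

All three were tested in a functional assay on Caco-2 cells (Homo sapiens) for inhibition, read by MTT assay, with a stated time of 48 h; on this read-out higher numbers stand for weaker inhibition and lower numbers for stronger inhibition. Compound 1 gives 25200 nM in this assay. Compound 2 gives 17500 nM. For compound 3 the assay reports only a limit, > 100000 nM, not a number.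

Going from compound 1 to compound 2 the change is 3-bromophenyl in place of 2-methoxyphenyl on an aromatic carbon, and it makes a 1.4-fold lower number from compound 1 to compound 2 (0.16 log units; within the scatter).

Compound 4 `COc1cc(/C=N/Nc2nc(-c3cccc(Br)c3)cs2)c(Br)c(Br)c1OC` has not yet been measured. It differs from compound 3 by 3-bromophenyl in place of 2-methoxyphenyl on an aromatic carbon, the same change as from compound 1 to compound 2. How the core of compound 3 differs from the core of compound 1 is not broken down here.

Since the earlier step stayed within the scatter, the step from compound 3 to compound 4 in this assay is expected to be of similar size, a number no higher from compound 3 to compound 4 (the limit leaves the size open). Compound 4 may well be reported only as a limit again because the limit of > 100000 nM in this assay, at which 1 of the 3 values shown sits, already holds compound 3. Compound 4 is expected to give about 100000 nM, with a likely range from 40000 nM to 300000 nM.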

Compound 4, half-maximal inhibitory concentration: > 100000 nM
Compound 4: no number, only a limit (the forecaster's own chance of this, stated with the estimate: 70%); the middle value sits exactly at the limit.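

In this assay compound 3 is reported only as a limit, > 100000 nM. Compound 4 is also reported only as a limit, > 100000 nM, and the step between the two cannot be read. The compounds shown leave open whether 3-bromophenyl in place of 2-methoxyphenyl changes the number at all on the core of compound 3.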